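Moving the acetyl group around the phenyl ring

The compounds below may be only part of what the source reports. "The series", "measured", "known", "first", "only" and "open" are said of these compounds alone.

Of the compounds shown here, three sharing one core have been measured in an assay on CHO-K1 cells for displacement of a labelled ligand from adenosine receptor A1 (Homo sapiens), tested at 10 uM; a lower number here means less inhibition, a higher number more inhibition at the concentration tested (going by the name of the read-out). Compound 2, `CCOC(=O)c1c(N)sc(-c2ccccc2)c1-c1cccc(C(F)(F)F)c1`, gives 83.6%. Compound 3, `CCOC(=O)c1c(N)sc(-c2cccc(C(C)=O)c2)c1-c1cccc(C(F)(F)F)c1`, gives 68.9%, the second highest of the three numbers, with compound 2 nearest above it and compound 1 furthest below. Within the data shown here, compound 1, `CC(=O)c1ccc(-c2sc(N)c(C(=O)c3ccccc3)c2-c2cccc(C(F)(F)F)c2)cc1`, gives 25.6%; its core carries a benzoyl group rather than the ethoxycarbonyl of the other two, so no single-change step joins it to them.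

Compound 4, `CCOC(=O)c1c(N)sc(-c2ccc(C(C)=O)cc2)c1-c1cccc(C(F)(F)F)c1`, differs from compound 3 in one place: 4-acetylphenyl in place of 3-acetylphenyl on an aromatic carbon. Among the measured compounds shown here, no measured step moves an acetyl group between positions on this ring. For the measured compounds named here, the only related step is a number 14.7 percentage points lower from compound 2 to compound 3 (beyond the scatter), which shows that an acetyl group on this ring matters to the read-out. Going by the values given here, compound 1 carries the 4-acetylphenyl group, but on a different core, so its number shows only that such a compound can sit low. For compound 4 the change is therefore expected to be a number 8.9 percentage points lower from compound 3 to compound 4 (within the scatter), modest and downward. Compound 4 is estimated at 60%, between 35% and 82%.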

Compound 4, a percentage reported as inhibition, at one concentration (the size of the read-out at that concentration, not a potency): 64.6%
Beside the measured number, compound 4's estimate is 4.6 percentage points below it; the range from low to high includes it.
By their numbers in this assay, from the lowest: compound 1; then compounds 4 and 3 (each within the scatter of the next); then compound 2.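

In this assay, exchanging 3-acetylphenyl for 4-acetylphenyl on the aromatic carbon next to the ring sulfur gives a number 4.3 percentage points lower from compound 3 to compound 4 (within the scatter), so these two acetyl placements cannot be told apart. The 4-acetylphenyl group also falls short of the plain phenyl group, with a number 19 percentage points lower from compound 2 to compound 4 (beyond the scatter), which matches the earlier a number 14.7 percentage points lower from compound 2 to compound 3 (beyond the scatter). With 4-acetylphenyl held constant, the core can now be compared directly: ethoxy in place of phenyl on the carbonyl carbon gives a number 39 percentage points higher from compound 1 to compound 4 (beyond the scatter), a large step.

From the compounds shown here alone, whether an amine or a carboxylic acid in place of the acetyl would give a number like those of the acetyl compounds, or a longer chain in place of the ethoxy would hold the number, remains open. No measurement shown here explains any of these steps.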